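This account rests on a few compounds, and the source may have more. Where it says the series, first, only, none or still open, it means among the compounds named here.

In a physicochemical assay for lipophilicity, at pH 7.4 (on this read-out higher numbers stand for higher lipophilicity and lower numbers for lower lipophilicity), compound 1 (`CC(C)CN(c1ccc(C#N)cc1)S(=O)(=O)c1ccc2c(c1)C(=O)CC(C1CCOCC1)O2`) gives 3.16 and compound 2 (`CCc1ccc(N(CC(C)C)S(=O)(=O)c2ccc3c(c2)C(=O)CC(CC2CCOCC2)O3)cc1`) gives 4.53 as the highest of the two numbers, with the gap between them beyond the scatter. Compound 3 (`CCc1ccc(N(CC(C)C)S(=O)(=O)c2ccc3c(c2)C(=O)CC(C2CCNCC2)O3)cc1`) has not yet been measured. It departs from compound 2 in one place, on a saturated ring carbon of a six-membered non-aromatic ring with 1 oxygen, where piperidin-4-yl stands in place of (oxan-4-yl)methyl (piperidin-4-yl in place of (oxan-4-yl)methyl on a saturated ring carbon) in the otherwise shared structure. Among the measured compounds shown here, no measured pair of compounds differs in one place only, so the expectation rests on the structural change alone. A large fall in this assay is expected, well beyond the scatter. The expected size of the change is a number 2.13 log units lower from compound 2 to compound 3 (beyond the scatter) as an estimate. For compound 3 the estimated value is 2.4 with an expected range from 1.6 to 3.2 in this measurement.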

Compound 3, distribution coefficient: 2.21
Compound 3: middle estimate off by 0.19 log units, on the high side; the measured number falls inside the stated range.
By their numbers in this assay, from the lowest: compound 3; then compound 1; then compound 2.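

In this assay, among the compounds shown here, piperidin-4-yl in place of (oxan-4-yl)methyl on a saturated ring carbon, next to the ring oxygen, gives a number 2.32 log units lower from compound 2 to compound 3 (beyond the scatter), the first change in one place that can be read here. This shows that the group at this position can move the read-out by a large amount. The change is not a single one, however: the entering group has one heavy atom fewer, nitrogen where the leaving group has oxygen, and a hydrogen-bond donor the leaving group lacks, and no measurement here explains the size of the step.

The compounds shown do not separate the exchange of ring atom from the loss of the methyl link. As far as these compounds go, a piperidin-4-ylmethyl group at this position, or a methyl group on the ring nitrogen of piperidin-4-yl, would address what remains open.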